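Aryl replacements at the shared core: growth inhibition

The compounds below may be only part of what the source reports. "The series", "measured", "known", "first", "only" and "open" are said of these compounds alone.

Measured compounds:
compound 1 `COc1ccc(-c2cn3ccnc3c(-c3ccc4ncn(C5CCCCC5)c4c3)n2)cc1`: 78.8%
compound 2 `c1ccc2c(-c3cn4ccnc4c(-c4ccc5ncn(C6CCCCC6)c5c4)n3)cccc2c1`: 4.46%
compound 3 `Fc1ccc(-c2cn3ccnc3c(-c3ccc4ncn(C5CCCCC5)c4c3)n2)cc1`: 7.59%

In a functional assay on HCT-15 cells (Homo sapiens) for inhibition, read by sulforhodamine B assay, with a stated time of 48 h, tested at 10 uM (on this read-out lower numbers stand for less inhibition and higher numbers for more inhibition at the one concentration tested (going by the name of the read-out)), compound 1 stands highest of the three numbers; compound 3 is nearest and compound 2 furthest, both beyond the scatter. The two steps away from compound 1 are large: a number 74.3 percentage points lower from compound 1 to compound 2 (beyond the scatter) and a number 71.2 percentage points lower from compound 1 to compound 3 (beyond the scatter). Between the two lower compounds the gap is small: a number 3.1 percentage points higher from compound 2 to compound 3 (within the scatter).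

Compound 4 `c1csc(-c2cn3ccnc3c(-c3ccc4ncn(C5CCCCC5)c4c3)n2)c1` differs from compound 1 by thiophen-2-yl in place of 4-methoxyphenyl on an aromatic carbon. Both measured replacements of the 4-methoxyphenyl of compound 1 gave large drops in this assay, so a drop beyond the scatter is expected here as well: a number 63.8 percentage points lower from compound 1 to compound 4 (beyond the scatter). For compound 4 the estimate is 15%, with a range from 3% to 45%.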

Compound 4, a percentage reported as inhibition, at one concentration (the size of the read-out at that concentration, not a potency): 2.33%
The estimate for compound 4 lay 12.7 percentage points above the measured number, outside the stated range (below it).
By their numbers in this assay, from the lowest: compounds 4, 2 and 3 (each within the scatter of the next); then compound 1.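

Thiophen-2-yl, a five-membered ring with sulfur, behaves at this position like the six-membered and fused aryl groups: in this assay the loss recurs (a number 76.5 percentage points lower from compound 1 to compound 4 (beyond the scatter)), and compound 4 sits within the scatter of the others (a number 5.3 percentage points lower from compound 3 to compound 4 (within the scatter); a number 2.1 percentage points lower from compound 2 to compound 4 (within the scatter)). Among the four compounds, only the 4-methoxyphenyl of compound 1 stands apart, so ring size alone does not separate compound 2, compound 3 and compound 4. No measurement here accounts for this.

Going by these compounds, whether the activity needs the methoxy group itself stays open. 4-Ethoxyphenyl, 4-hydroxyphenyl or 4-aminophenyl would address that.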